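Switching the ring nitrogen substituent on an anticonvulsant scaffold

The source may report more compounds than this note shows. Statements on the series, on what has been measured and on what is new or still open speak of the compounds shown alone.

Compound 1 `O=C1NC(=O)C2(CC2c2ccc3cccc(OCc4ccccc4)c3n2)N1` is the parent of this small set. In a functional assay on the whole organism (strain Kunming) with Mus musculus as the target, with a stated time of 0.5 h (a higher number here means that more compound is needed for the effect, a lower number that less compound is needed), compound 1 gives 300 mg/kg. Compound 3 `O=C1NC2(CC2c2ccc3cccc(OCc4ccccc4)c3n2)C(=O)N1Cc1ccccc1` gives 300 mg/kg, and compound 1 stands level with compound 3 at the digits shown, the two together being the highest numbers of the three. Compound 2 `CC(C)N1C(=O)NC2(CC2c2ccc3cccc(OCc4ccccc4)c3n2)C1=O`, with isopropyl on the ring nitrogen, gives 100 mg/kg, the lowest number of the set.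

Compound 4 `COc1ccc(N2C(=O)NC3(CC3c3ccc4cccc(OCc5ccccc5)c4n3)C2=O)cc1` differs from compound 1 in one place: 4-methoxyphenyl in place of hydrogen on an amide-type nitrogen in a ring. Among the compounds with values here, two measured steps bear on this. Putting isopropyl in place of hydrogen gave a 3.0-fold lower number from compound 1 to compound 2 (0.48 log units; beyond the scatter), whereas putting benzyl, which also carries an aromatic ring, in place of hydrogen gave no change at the digits printed from compound 1 to compound 3 (within the scatter). The new group sits at the same ring nitrogen and, like benzyl, brings an aromatic ring, so no step beyond the scatter is expected, with at most a small shift toward a lower number.

For compound 4 the expected value in this assay is 200 mg/kg, with a range from 100 mg/kg to 300 mg/kg. This estimate corresponds to an expected step of a 1.5-fold lower number from compound 1 to compound 4 (0.18 log units; within the scatter).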

Compound 4, minimum effective dose: 300 mg/kg
Compound 4: the middle estimate sits 1.5-fold (0.18 log units) below what was measured; the range from low to high includes it.
By their numbers in this assay, from the lowest: compound 2; then compounds 1, 3 and 4 (each within the scatter of the next).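

Placing 4-methoxyphenyl on the ring nitrogen gives no change at the digits printed from compound 1 to compound 4 (within the scatter), and exchanging benzyl for it gives no change at the digits printed from compound 3 to compound 4 (within the scatter). In this assay, a second group carrying an aromatic ring therefore reads the same as hydrogen, and attaching that ring through a different group at this nitrogen does not separate compound 3 from compound 4. Within the data shown here, the step from isopropyl gives a 3.0-fold higher number from compound 2 to compound 4 (0.48 log units; beyond the scatter), which leaves compound 2 as the only one of the four compounds set apart, while compounds 1, 3 and 4 stay together; nothing measured here explains why isopropyl differs from the other three groups.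

The compounds shown leave open whether other carbon-only groups at this ring nitrogen, such as ethyl, tert-butyl or cyclohexyl, would match compound 2 or fall in with the other three compounds. They also leave open whether the methoxy group on compound 4 has any bearing on its number, a question that plain phenyl or 4-chlorophenyl at the same nitrogen could address.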